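The source may report more compounds than this note shows. Statements on the series, on what has been measured and on what is new or still open speak of the compounds shown alone.

Compound 1 `COc1ccccc1C(=O)Nc1[nH]nc(-c2ccccn2)c1C1CC1` is the starting point here. In an ADME assay on liver (Mesocricetus auratus) for metabolic stability, using microsomes (on this read-out lower numbers stand for slow clearance and higher numbers for fast clearance), compound 1 gives > 100 mL.min-1.g-1, which is a limit of the assay and not a number. Compound 1 therefore stands at the limit of > 100 mL.min-1.g-1 in this assay, at which 1 of the 3 values shown sits. Two other compounds have full numbers: compound 2 `N#Cc1ccc(OC2CCN(C(=O)Nc3cc(-c4ccccn4)n[nH]3)CC2)cc1` gives 30.8 mL.min-1.g-1 in this assay, and compound 3 `O=C(Nc1cc(-c2ccccn2)n[nH]1)N1CCN(c2ccc(F)cc2)CC1` gives 46.5 mL.min-1.g-1 in this assay. Compound 4 `O=C(NCc1ccccc1)Nc1[nH]nc(-c2ccccn2)c1C1CC1` has not been measured; it differs from compound 1 in one place: benzylamino in place of 2-methoxyphenyl on a carbonyl carbon. For the measured compounds named here, compound 1 offers only a limit, so no step between measured compounds is available. Compound 4 is expected to fall beyond the scatter, downward, with the step of an at least 1.8-fold lower number from compound 1 to compound 4 (0.25 log units; that floor lies within the scatter). For compound 4 the estimate in this assay is 55 mL.min-1.g-1, within 22 mL.min-1.g-1 to 140 mL.min-1.g-1.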

Compound 4, intrinsic clearance in microsomes: > 400 mL.min-1.g-1
Compound 4 ended at the assay's limit (the forecaster's own chance of this, stated with the estimate: 25%); at least 7.2-fold (0.86 log units) between middle value and limit.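

Compound 1 and compound 4 each give only a limit in this assay, not a number, so the step between them cannot be read. The compounds shown leave open whether benzylamino or 2-methoxyphenyl gives slower clearance.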